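Replacing a fluoro with a nitro on the phenyl ring

The source may hold more compounds than are shown below. What is called first, only, known or untested is meant among the compounds shown, and "the series" means these compounds.

Among the compounds with values here, compound 3 `C[C@H]1CC[C@@H]2[C@@H](OC(=O)[C@]23CC(c2ccc(F)cc2)N(c2ccccc2)O3)[C@]2(C)C(=O)C=C[C@@]12O` is the most lipophilic of the three compounds measured so far: in a physicochemical assay for lipophilicity (on this read-out higher numbers stand for higher lipophilicity and lower numbers for lower lipophilicity), compound 3 gives 3.35. Its nearest neighbour is compound 2 `C[C@H]1CC[C@@H]2[C@@H](OC(=O)[C@]23CC(c2ccccc2Cl)=NO3)[C@]2(C)C(=O)C=C[C@@]12O`, which in this assay gives 2.09, and furthest away is compound 1 `C[C@H]1CC[C@@H]2[C@@H](OC(=O)[C@]23CC(c2cccc([N+](=O)[O-])c2)=NO3)[C@]2(C)C(=O)C=C[C@@]12O`, which in this assay gives 1.37. Compound 4 `C[C@H]1CC[C@@H]2[C@@H](OC(=O)[C@]23CC(c2ccc([N+](=O)[O-])cc2)N(c2ccccc2)O3)[C@]2(C)C(=O)C=C[C@@]12O` has not yet been measured. It differs from compound 3 in one place: nitro in place of fluoro on an aromatic carbon, on an aromatic carbon of a six-membered aromatic ring of carbon only, para to a large group.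

Within the data shown here, the only measured step that speaks to this change is the one between compound 1 and compound 2, where a number 0.72 log units higher from compound 1 to compound 2 (beyond the scatter) was seen. There a nitro-bearing phenyl gave the lower number and a chloro-bearing phenyl the higher one, on a different carbon of the shared core and at a different ring position, so it is only a rough guide. On that basis the expected step of a number 0.40 log units lower from compound 3 to compound 4 (beyond the scatter) is a modest decrease, beyond the scatter. Compound 4 is therefore expected to give about 2.95 in this assay, most likely between 2.5 and 3.4.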

Compound 4, partition coefficient: 3.15
For compound 4 the middle estimate is 0.20 log units below the measured one; the measured number falls inside the stated range.
By their numbers in this assay, from the lowest: compound 1; then compound 2; then compounds 4 and 3 (each within the scatter of the next).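

At this position, on an aromatic carbon of a six-membered aromatic ring of carbon only, para to a large group, changing 4-fluorophenyl to 4-nitrophenyl gives in this assay a step that cannot be told from repeat-measurement noise (a number 0.20 log units lower from compound 3 to compound 4 (within the scatter)). The earlier nitro-bearing comparison was a different change, with chloro as the partner group and at another place on the shared core, and its step lay beyond the scatter (a number 0.72 log units higher from compound 1 to compound 2 (beyond the scatter)), so compounds 3 and 4 show that a nitro-bearing phenyl does not always come with a clear difference in this read-out. No measurement here accounts for this result.

The compounds shown leave open whether the same place tolerates other swaps just as quietly, for example a plain hydrogen, an amine or a carboxylic acid in place of the fluoro. They also leave open whether the nitro would give a similar result elsewhere on this phenyl ring, and whether compound 1 and compound 2 differ through the group, its position on the ring, or both.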